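The source may report more compounds than this note shows. Statements on the series, on what has been measured and on what is new or still open speak of the compounds shown alone.

Measured compounds:
- compound 1, `CC(C)(C)C1=CC(=O)C=C(NCC(=O)O)C1=O`: 85000 nM
- compound 2, `C[C@H](NC1=CC(=O)C=C(C(C)(C)C)C1=O)C(=O)O`: 77600 nM
- compound 3, `CC1=CCC[C@H]2[C@](C)(CC3=CC(=O)C=C(N[C@@H](CC(C)C)C(=O)O)C3=O)[C@@H](C)CC[C@]12C`: 11200 nM

In a functional assay on K562 cells (Homo sapiens) for cytotoxicity, read by MTT assay, with a stated time of 72 h (on this read-out lower numbers stand for stronger inhibition and higher numbers for weaker inhibition), compound 1 gives 85000 nM, the highest of the three numbers. Its nearest neighbour is compound 2, which in this assay gives 77600 nM; the furthest is compound 3, which in this assay gives 11200 nM and sits on a different core, so its gap from compound 1 cannot be tied to a single change.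

Compound 4, `CC(C)[C@@H](NC1=CC(=O)C=C(C(C)(C)C)C1=O)C(=O)O`, keeps the core of compound 1 and differs from it in one place: isopropyl in place of hydrogen on a saturated chain carbon bound to an amine nitrogen and a carbonyl carbon. For the measured compounds named here, the one measured step that bears on this is a 1.1-fold lower number from compound 1 to compound 2 (0.04 log units; within the scatter), a change at the same place that left the number essentially where it was. Going by the values given here, a larger group entering at that place has no direct precedent on this core, so the expectation for compound 4 is a small step, a 1.4-fold lower number from compound 1 to compound 4 (0.15 log units; within the scatter), hardly beyond the scatter. The estimate for compound 4 in this assay is 60000 nM, with a range from 25000 nM to 150000 nM.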

Compound 4, half-maximal inhibitory concentration: 57800 nM
Estimate against measurement, compound 4: 1.0-fold (0.02 log units) above; measured number inside the range.
By their numbers in this assay, from the lowest: compound 3; then compounds 4, 2 and 1 (each within the scatter of the next).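

In this assay, isopropyl in place of hydrogen on a saturated chain carbon bound to an amine nitrogen and a carbonyl carbon gives a 1.5-fold lower number from compound 1 to compound 4 (0.17 log units; within the scatter) on the shared core. Compound 2 had tested this place only with methyl, whereas isopropyl brings 3 heavy atoms and the step still stays within the scatter, so neither of the two groups shown here moves the number measurably at this place. Nothing measured here offers a reason for this flat result.

From the compounds shown here alone, whether a carboxylic acid, an amine or a phenyl ring at this place would move the number remains open. Also open, going by these compounds, is whether this place has any part in the lower number of compound 3, 11200 nM, which sits on a different core and so cannot be compared in a single step.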